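The source may hold more compounds than are shown below. What is called first, only, known or untested is meant among the compounds shown, and "the series" means these compounds.

Measured so far:
compound 1 `CCCOC(=O)C1=C(C)NC(=O)NC1c1ccsc1` – 6%
compound 2 `CCSC(=O)C1=C(C)NC(=O)NC1c1ccsc1` – 2%

Both compounds share one core and differ only in the group on the carbonyl carbon. In an assay on membranes from HeLa cells for displacement of a labelled ligand from adenosine receptor A3 (Homo sapiens), read by scintillation counting, with a stated time of 180 min, tested at 1 uM (a higher number here means more inhibition at the concentration tested (going by the name of the read-out), a lower number less inhibition), compound 1 gives 6%, and compound 2 gives 2%. The step of a number 4 percentage points lower from compound 1 to compound 2 (within the scatter) lies within the scatter, so the two numbers cannot be told apart; compound 2 stands alongside compound 1 at a level where very little of the labelled ligand is displaced.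

Compound 3 `CC1=C(C(=O)OC2CCCC2)C(c2ccsc2)NC(=O)N1` has not yet been measured. It keeps the core of compound 2 and changes only the group on the carbonyl carbon:
cyclopentyloxy in place of ethylsulfanyl on a carbonyl carbon

Within the data shown here, the only measured step that touches this position is a number 4 percentage points lower from compound 1 to compound 2 (within the scatter), and it brought no change beyond the scatter. Nothing measured here speaks for a large move in either direction, so a step of a number 3 percentage points higher from compound 2 to compound 3 (within the scatter) is expected, that is, none beyond the scatter. For compound 3 in this assay the estimate is 5%, with a range from -8% to 20%.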

Compound 3, a percentage reported as inhibition, at one concentration (the size of the read-out at that concentration, not a potency): 5%
Compound 3: middle estimate and measured number agree at the digits printed, and the stated range covers the measured number.
By their numbers in this assay, from the lowest: compounds 2, 3 and 1 (each within the scatter of the next).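

In this assay, putting cyclopentyloxy in place of ethylsulfanyl gives a number 3 percentage points higher from compound 2 to compound 3 (within the scatter), and putting cyclopentyl in place of propyl on an oxygen next to a carbonyl group gives a number 1 percentage points lower from compound 1 to compound 3 (within the scatter). The earlier compounds shown here carried only open chains at this position, whereas this one brings a five-membered non-aromatic ring of carbon only and 6 heavy atoms in place of the 3 of ethylsulfanyl, yet neither step lies beyond the scatter, so the ring and the extra atoms bring no change that these numbers can detect. Nothing available explains why the numbers stay at this level.

All three compounds sit so close together and so low that they do not show whether this position can influence the read-out at all. On these data alone, it remains open whether a group of another kind on the carbonyl carbon, such as an amine, a benzyloxy group or a much longer carbon chain on the oxygen, would move the number beyond the scatter.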